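Aryl swap on the imidazopyrazine series

This account rests on a few compounds, and the source may have more. Where it says the series, first, only, none or still open, it means among the compounds named here.

Measured so far:
compound 1 `c1cn2cc(-c3ccsc3)nc(-c3ccc4ncn(C5CCCCC5)c4c3)c2n1` gives 5.68%
compound 2 `CCc1ccc(-c2cn3ccnc3c(-c3ccc4ncn(Cc5ccccc5)c4c3)n2)cc1` gives 68.8%

Among the measured compounds shown here, only two compounds have been run in a functional assay on HT-29 cells (Homo sapiens) for inhibition, read by sulforhodamine B assay, with a stated time of 48 h, tested at 10 uM; on this read-out lower numbers stand for less inhibition and higher numbers for more inhibition at the one concentration tested (going by the name of the read-out). Compound 2 holds the higher of the two numbers, and its nearest neighbour, compound 1, sits well below it, a gap beyond the scatter. Compound 1 and compound 2 differ in several places at once, so no single step can be read from them.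

Compound 3 `Cc1cccc(-c2cn3ccnc3c(-c3ccc4ncn(Cc5ccccc5)c4c3)n2)c1` is the next entry. Relative to compound 2 the change is 3-methylphenyl in place of 4-ethylphenyl on an aromatic carbon. For the measured compounds named here, no step of this kind has yet been measured in this assay, so the expectation rests on compound 2 alone: a moderate downward step a number 13.8 percentage points lower from compound 2 to compound 3 (beyond the scatter) is expected, since the shift from a para to a meta substituent and the shorter chain are each small changes, and the result may well stay within reach of the scatter. Compound 3 is estimated at 55%, in the range 30% to 78%.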

Compound 3, a percentage reported as inhibition, at one concentration (the size of the read-out at that concentration, not a potency): 42%
The estimate for compound 3 lay 13 percentage points above the measured number, within the range that was stated.
By their numbers in this assay, from the lowest: compound 1; then compound 3; then compound 2.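

Among the compounds shown here, with the rest of the structure held constant, this assay moves a number 26.8 percentage points lower from compound 2 to compound 3 (beyond the scatter) when 3-methylphenyl takes the place of 4-ethylphenyl, the first single-place step. The number therefore responds to the group on this aromatic carbon, even though both groups are carbon-only six-membered aromatic rings with no hydrogen-bond donors or acceptors and no net charge. Nothing measured here accounts for the size of this step.

The step alters the chain and its place on the ring together, and 4-methylphenyl or 3-ethylphenyl would be needed to separate the two. Also open, as far as these compounds go, is whether an amine, a carboxylic acid or a longer chain such as 4-propylphenyl on this ring would keep or lose the inhibition.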